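From 4-methylbenzyl to propyl on the sulfur

The source may report more compounds than this note shows. Statements on the series, on what has been measured and on what is new or still open speak of the compounds shown alone.

In a functional assay on PC-9 cells (Homo sapiens) for inhibition, read by MTT assay, with a stated time of 72 h (a lower number here means a stronger inhibitor, a higher number a weaker inhibitor), compound 2 `Cc1cc(Nc2cc(-c3ccccc3)[nH]n2)n2nc(SCc3ccc(Cl)cc3)nc2n1` gives 6710 nM and compound 3 `Cc1ccc(CSc2nc3nc(C)cc(Nc4cc(-c5ccccc5)[nH]n4)n3n2)cc1` gives 7310 nM. These two values lie within the scatter of each other, with a 1.1-fold higher number from compound 2 to compound 3 (0.04 log units; within the scatter). Compound 1 `Cc1cc(Nc2cc(-c3ccccc3)[nH]n2)n2nc(SCC3CCCCC3)nc2n1` reads > 50000 nM, which is a limit of the assay and not a number. Compound 3 therefore stands level with compound 2, and the only other entry is that limit.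

Compound 4 `CCCSc1nc2nc(C)cc(Nc3cc(-c4ccccc4)[nH]n3)n2n1` has ethyl in place of 4-methylphenyl on a saturated chain carbon bound to a sulfur. This removes the aromatic ring at that place. The closest guides are an at least 7.4-fold lower number from compound 1 to compound 2 (0.87 log units; beyond the scatter) and an at least 6.8-fold lower number from compound 1 to compound 3 (0.83 log units; beyond the scatter), where the compounds with the aromatic ring have the lower numbers. Among the compounds with values here, no measured compound carries a propyl group, so the transfer is uncertain. A step to a higher number is expected, of modest size or more, and a 2.7-fold higher number from compound 3 to compound 4 (0.44 log units; beyond the scatter) is the estimated step. The estimate for compound 4 is 20000 nM, with an expected range from 7000 nM to 50000 nM.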

Compound 4, half-maximal inhibitory concentration: > 50000 nM
Compound 4: only a limit was reported (the forecaster's own chance of this, stated with the estimate: 30%); middle value at least 2.5-fold (0.39 log units) away from the limit.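

In this assay, ethyl in place of 4-methylphenyl on a saturated chain carbon bound to a sulfur gives an at least 6.8-fold higher number from compound 3 to compound 4 (0.83 log units; beyond the scatter), and ethyl in place of 4-chlorophenyl gives an at least 7.4-fold higher number from compound 2 to compound 4 (0.87 log units; beyond the scatter). Within the data shown here, until this result, cyclohexyl was the only group without an aromatic ring at this place; with propyl as a second such group, the two compounds carrying an aromatic ring here have measured values and the two without one do not, with no compound among the four going against this. The step between compound 1 and compound 4 cannot be read, because both values are limits of the assay: the limit of > 50000 nM in this assay, at which 2 of the 4 values shown sit.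

Open, from the compounds shown here alone, is whether a ring-free group can give a measured value here at all, for instance a longer chain or a chain ending in an amine. Also open, going by these compounds, is how an unsubstituted benzyl or a pyridylmethyl group would read at this place.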